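Swapping fluoro for ethoxy in compound 4

The source may report more compounds than this note shows. Statements on the series, on what has been measured and on what is new or still open speak of the compounds shown alone.

compound 1 `CCCCNc1nc(SC)nc2ncccc12` gives 270 nM
compound 2 `CSc1nc(Nc2ccccc2)c2cccnc2n1` gives 15900 nM
compound 3 `CSc1nc(Nc2ccc(F)cc2)c2cccnc2n1` gives 2620 nM

In a functional assay (Nicotiana tabacum) (a higher number here means a weaker inhibitor, a lower number a stronger inhibitor), compound 3 stands in the middle of the three measured numbers: its number is lower than that of compound 2 and higher than that of compound 1. The next compound, compound 4 `CCOc1ccc(Nc2nc(SC)nc3ncccc23)cc1`, carries ethoxy in place of fluoro on an aromatic carbon, para to a large group (ethoxy in place of fluoro on an aromatic carbon).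

The closest measured change sits on that same carbon: fluoro in place of hydrogen gave a 6.1-fold lower number from compound 2 to compound 3 (0.78 log units; beyond the scatter) and that step is modest. The other change, phenyl in place of butyl on the nitrogen, gave a 59-fold higher number from compound 1 to compound 2 (1.77 log units; beyond the scatter) and that step is large. So the group on the nitrogen can shift the number strongly, but neither step involves ethoxy, and the data do not settle a direction. The expectation is therefore no step beyond the scatter, with a modest step either way still possible.

The estimated value for compound 4 is 2500 nM with 500 nM to 12000 nM as its expected range. By this estimate the expected change is a 1.0-fold lower number from compound 3 to compound 4 (0.02 log units; within the scatter) at the middle of the range.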

Compound 4, half-maximal inhibitory concentration: 5420 nM
For compound 4 the middle estimate is 2.2-fold (0.34 log units) below the measured one; measured number inside the range.
By their numbers in this assay, from the lowest: compound 1; then compound 3; then compound 4; then compound 2.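

In this assay, ethoxy on this aromatic carbon gives a 2.1-fold higher number from compound 3 to compound 4 (0.32 log units; beyond the scatter), so of the two groups, fluoro gives the stronger inhibitor here. Compared with plain hydrogen on the same carbon, ethoxy still gives a 2.9-fold lower number from compound 2 to compound 4 (0.47 log units; beyond the scatter), which shows that fluoro is not the only group here that lowers the number and that ethoxy, with its three heavy atoms, also does so, though less far than fluoro, with its one. Nothing available explains why these three compounds fall in this order.

The compounds shown leave open whether the number on this carbon follows the length of the chain, since a methoxy group or a longer butoxy chain could fall on either side of ethoxy. They also leave open how an amine on the same carbon would compare with fluoro and ethoxy.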